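Bromo to Fluoro, Seen Once and Tried Again

This account rests on a few compounds, and the source may have more. Where it says the series, first, only, none or still open, it means among the compounds named here.

Measured in a functional assay on HL-60 cells (Homo sapiens) for cytotoxicity, read by MTT assay, with a stated time of 72 h; on this read-out higher numbers stand for weaker inhibition and lower numbers for stronger inhibition:
Compound 1, `O=S(=O)(c1ccc(Br)cc1)c1nc2ccccc2nc1N1CCCC1`, gives 6070 nM.
Compound 2, `O=S(=O)(c1ccc(F)cc1)c1nc2ccccc2nc1N1CCCC1`, gives 12800 nM.
Compound 3, `O=S(=O)(c1ccc(Br)cc1)c1nc2ccccc2nc1N1CCCC(O)C1`, gives 3430 nM.

Compound 2 differs from compound 1 by fluoro in place of bromo on an aromatic carbon, and that change gave a 2.1-fold higher number from compound 1 to compound 2 (0.32 log units; beyond the scatter). Compound 3 differs from compound 1 by 3-hydroxypiperidin-1-yl in place of pyrrolidin-1-yl on an aromatic carbon, which gave a 1.8-fold lower number from compound 1 to compound 3 (0.25 log units; within the scatter). Compound 4, `O=S(=O)(c1ccc(F)cc1)c1nc2ccccc2nc1N1CCCC(O)C1`, has not been measured; it differs from compound 3 by fluoro in place of bromo on an aromatic carbon, the same change as between compound 1 and compound 2, at the same place, while the two cores differ as described under (3-hydroxypiperidin-1-yl in place of pyrrolidin-1-yl on an aromatic carbon). For the measured compounds named here, the step from compound 3 to compound 4 in this assay is expected to be a 2.1-fold higher number from compound 3 to compound 4 (0.32 log units; beyond the scatter), resting on the single earlier step of a 2.1-fold higher number from compound 1 to compound 2 (0.32 log units; beyond the scatter). Compound 4 is therefore estimated at 7200 nM, expected to lie between 3400 nM and 15000 nM.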

Compound 4, half-maximal inhibitory concentration: 2620 nM
The estimate for compound 4 lay 2.7-fold (0.44 log units) above the measured number; measured number below the stated range.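

In this assay, fluoro in place of bromo gave a 1.3-fold lower number from compound 3 to compound 4 (0.12 log units; within the scatter), so this change did not carry over from one core to the other: the same change on two cores in this assay, a 2.1-fold higher number (0.32 log units; beyond the scatter) from compound 1 to compound 2 and a 1.3-fold lower number (0.12 log units; within the scatter) from compound 3 to compound 4, 2.8-fold (0.44 log units) apart, beyond the scatter of two such steps. Read the other way, 3-hydroxypiperidin-1-yl in place of pyrrolidin-1-yl gave a 4.9-fold lower number from compound 2 to compound 4 (0.69 log units; beyond the scatter) with fluoro present, and this change too differed between the two cores: the same change on two cores in this assay, a 1.8-fold lower number (0.25 log units; within the scatter) from compound 1 to compound 3 and a 4.9-fold lower number (0.69 log units; beyond the scatter) from compound 2 to compound 4, 2.8-fold (0.44 log units) apart, beyond the scatter of two such steps. For the compounds shown here, the result of either change therefore depends here on the group at the other place, but these compounds give only one comparison, and they do not show why the steps differ or whether the same would hold for other groups.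

Still open, as far as these compounds go, is how a chloro or methoxy group would behave in place of the bromo or fluoro. Also open, from the compounds shown here alone, is whether a morpholine or piperazine in place of the pyrrolidin-1-yl would show the same dependence.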